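Swapping pyrrolidin-1-yl for butylamino on a thiocarbonyl carbon

The source may hold more compounds than are shown below. What is called first, only, known or untested is meant among the compounds shown, and "the series" means these compounds.

Measured in a functional assay on K562 cells (Homo sapiens) for cytotoxicity, read by MTT assay, with a stated time of 72 h; a lower number here means a stronger inhibitor, a higher number a weaker inhibitor:
Compound 1 `CC(C)NC(=S)N/N=C1\CC(c2ccc(O)cc2)Oc2cc(O)ccc21`: 21300 nM
Compound 2 `Oc1ccc(C2C/C(=N\NC(=S)N3CCCC3)c3ccc(O)cc3O2)cc1`: 17300 nM

Compound 2 stands within the usual scatter of compound 1, so these two numbers cannot be told apart. Compound 3 `CCCCNC(=S)N/N=C1\CC(c2ccc(O)cc2)Oc2cc(O)ccc21` has butylamino in place of pyrrolidin-1-yl on a thiocarbonyl carbon. Going by the values given here, one measured step bears on this, made on the same carbon: a 1.2-fold lower number from compound 1 to compound 2 (0.09 log units; within the scatter). Among the compounds with values here, with only that small step as a guide, no change beyond the scatter is expected in this assay. The expected step is a 1.1-fold higher number from compound 2 to compound 3 (0.04 log units; within the scatter). For compound 3 the estimated value is 19000 nM, with an expected range of 9500 nM to 38000 nM.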

Compound 3, half-maximal inhibitory concentration: 17000 nM
Beside the measured number, compound 3's estimate is 1.1-fold (0.05 log units) above it; the range from low to high includes it.
By their numbers in this assay, from the lowest: compounds 3, 2 and 1 (each within the scatter of the next).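

In this assay, replacing the pyrrolidin-1-yl ring with open-chain butylamino, which brings a hydrogen-bond donor to the thiocarbonyl carbon, gives a 1.0-fold lower number from compound 2 to compound 3 (0.01 log units; within the scatter) and so no readable difference. Butyl in place of isopropyl on the amide-type nitrogen gives a 1.3-fold lower number from compound 1 to compound 3 (0.10 log units; within the scatter) and likewise cannot be told apart, so all three groups read alike here. No evidence is available on what lies behind this.

Going by these compounds, whether a different kind of group on this carbon, such as phenylamino or a morpholin-4-yl ring, would move the number beyond the scatter remains open.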